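The source may report more compounds than this note shows. Statements on the series, on what has been measured and on what is new or still open speak of the compounds shown alone.

Among the measured compounds shown here, in an in vitro ADME assay on microsomes (Homo sapiens) for metabolic stability (a lower number here means that the compound disappears faster, a higher number that the compound lasts longer), compound 3 `CCc1nc(N(CC2CC2)CC2CC2)c(CC)nc1-c1ccc(Cl)cc1Cl` gives 0.133 h and sits at the low end of the three compounds measured so far. Compound 2 `CCc1nc(-c2ccc(Cl)cc2Cl)c(CC)nc1NC(C1CC1)C1CC1` shares that low end, with 0.183 h as its value. Compound 1 `CCC(CC)Nc1nc(OC)c(-c2ccc(Cl)cc2Cl)nc1C` gives 0.933 h on the same read-out, and the gap between it and compound 3 lies outside the scatter.

In compound 4 `CCCN(CCN(C)C)c1nc(CC)c(-c2ccc(Cl)cc2Cl)nc1CC`, not yet measured, (2-(dimethylamino)ethyl)(propyl)amino stands in place of bis(cyclopropylmethyl)amino on an aromatic carbon (2-(dimethylamino)ethyl)(propyl)amino in place of bis(cyclopropylmethyl)amino on an aromatic carbon and the rest of compound 3 stays as it is. For the measured compounds named here, only one measured step bears on this change. With bis(cyclopropylmethyl)amino in place of (dicyclopropylmethyl)amino at the same position, a 1.4-fold lower number from compound 2 to compound 3 (0.14 log units; within the scatter) stayed within the scatter. Compound 1 differs from compound 3 in more than its amino group, so it offers no clean comparison. Going by the values given here, no measured compound carries the entering group, which leaves that single small step as thin support and calls for a wide range.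

In this assay the expected move is a 1.5-fold higher number from compound 3 to compound 4 (0.18 log units; within the scatter) and no change beyond the scatter is anticipated. For compound 4 the estimated half-life is 0.2 h with an expected range from 0.08 h to 0.55 h in repeated measurements.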

Compound 4, half-life: 0.0833 h
For compound 4 the middle estimate is 2.4-fold (0.38 log units) above the measured one, and the stated range covers the measured number.
By their numbers in this assay, from the lowest: compounds 4, 3 and 2 (each within the scatter of the next, the first and the last beyond it); then compound 1.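

In this assay, swapping bis(cyclopropylmethyl)amino for (2-(dimethylamino)ethyl)(propyl)amino on this aromatic carbon gives a 1.6-fold lower number from compound 3 to compound 4 (0.20 log units; within the scatter), so at this position a chain with no ring and a second nitrogen reads the same as the group with two three-membered rings. Set against (dicyclopropylmethyl)amino, the same chain gives a 2.2-fold lower number from compound 2 to compound 4 (0.34 log units; beyond the scatter), a modest difference and the only one among the amino groups at this position that passes the scatter, which shows that this place can shift the half-life, if only slightly, while the shared core stays as it is. Nothing available explains either step.

The swap removes the cyclopropyl rings and brings in the dimethylamino group together, so the compounds shown cannot separate the two changes; a plain dipropylamino group in the same place would be needed to tell them apart. From the compounds shown here alone, it also remains open whether any group here, such as a chain ending in a carboxylic acid or a morpholine, would move the half-life upward rather than leave it in this low range.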